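This account rests on a few compounds, and the source may have more. Where it says the series, first, only, none or still open, it means among the compounds named here.

In a physicochemical assay for solubility (a lower number here means a less soluble compound, a higher number a more soluble compound), compound 1 `O=C(O)c1ccc(C(=O)/C(=C\c2ccc(Cl)c([N+](=O)[O-])c2)SCc2ccc(Cl)cc2)cc1` gives < 1000 ug/mL as a limit and not a number. Compound 2 `COc1cc(/C=C(/SCc2ccc(Br)cc2)C(=O)c2ccc(C(=O)O)cc2)ccc1F` gives < 1000 ug/mL as a limit too. Compound 3 `O=C(O)c1ccc(C(=O)/C(=C\c2ccc(F)c([N+](=O)[O-])c2)[S+]([O-])Cc2ccc(Br)cc2)cc1` gives < 1000 ug/mL as a limit too. Compound 2 therefore has no exact number, and the whole set comes down to the limit of < 1000 ug/mL in this assay, at which 3 of the 3 values shown sit, and nothing finer. Going by the values given here, compound 4 `O=C(O)c1ccc(C(=O)/C(=C\c2ccc(O)c(Br)c2)SCc2ccc(Br)cc2)cc1` differs from compound 2 by having 3-bromo-4-hydroxyphenyl in place of 4-fluoro-3-methoxyphenyl on a double-bonded chain carbon bound to a double-bonded chain carbon as its only change. Among the compounds with values here, no measured step shows what such a swap does, so no shift beyond the usual scatter is expected. The estimated step that the limit leaves unreadable from compound 2 to compound 4 stays within that scatter. For compound 4 the expected value is 700 ug/mL with an estimated range of 300 ug/mL to 1200 ug/mL and another limit is likely.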

Compound 4, solubility: < 1000 ug/mL
Compound 4 ended at the assay's limit (the forecaster's own chance of this, stated with the estimate: 85%); the middle value lies beyond the limit too.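

No step can be read from compound 2 to compound 4, because both values are limits and not numbers: the limit of < 1000 ug/mL in this assay, at which 4 of the 4 values shown sit.

On these data alone, what 3-bromo-4-hydroxyphenyl in place of 4-fluoro-3-methoxyphenyl does in this assay stays open, as does whether these compounds differ at all.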